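This account rests on a few compounds, and the source may have more. Where it says the series, first, only, none or still open, it means among the compounds named here.

Measured compounds:
Compound 1 `CC1(C)[C@H]2CC[C@]1(C)N(Cc1cn(-c3cccc(C#N)c3)nn1)C(=O)C2` gives 250 nM in a functional assay on SGC-7901 cells (Homo sapiens) for inhibition, read by MTT assay, with a stated time of 24 h; on this read-out lower numbers stand for stronger inhibition and higher numbers for weaker inhibition.
Compound 2 `Cc1ccccc1-n1cc(CN2C(=O)C[C@@H]3CC[C@@]2(C)C3(C)C)nn1` gives 350 nM in this assay.
Compound 3 `CC1(C)[C@H]2CC[C@]1(C)N(Cc1cn(-c3ccc(Cl)cc3)nn1)C(=O)C2` gives 410 nM in this assay.

Of the three numbers, that of compound 1 is the smallest, but nothing separates the three compounds in this assay: the step of a 1.4-fold higher number from compound 1 to compound 2 (0.15 log units; within the scatter) and the step of a 1.6-fold higher number from compound 1 to compound 3 (0.21 log units; within the scatter) are both within the scatter, and so is the step of a 1.2-fold higher number from compound 2 to compound 3 (0.07 log units; within the scatter). Every one of these steps is the same kind of change, one aryl group exchanged for another on the aromatic nitrogen of the shared core, and none of them moved the read-out beyond the scatter.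

Compound 4 `COc1ccc(-n2cc(CN3C(=O)C[C@@H]4CC[C@@]3(C)C4(C)C)nn2)cc1` repeats that kind of change from compound 1: 4-methoxyphenyl in place of 3-cyanophenyl on an aromatic nitrogen. The three measured steps all bear on it, and all were within the scatter, so no step beyond the scatter is expected in either direction; the expected step is a 1.3-fold higher number from compound 1 to compound 4 (0.12 log units; within the scatter). Among the compounds with values here, compound 4 is therefore estimated to give 330 nM in this assay, with a range from 150 nM to 800 nM, the range kept wide because only three aryl groups have been compared so far.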

Compound 4, half-maximal inhibitory concentration: 480 nM
Beside the measured number, compound 4's estimate is 1.5-fold (0.16 log units) below it, and the stated range covers the measured number.
By their numbers in this assay, from the lowest: compounds 1, 2, 3 and 4 (each within the scatter of the next).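

With 4-methoxyphenyl on the aromatic nitrogen, the shared core still shows no step beyond the scatter in this assay (a 1.9-fold higher number from compound 1 to compound 4 (0.28 log units; within the scatter); a 1.4-fold higher number from compound 2 to compound 4 (0.14 log units; within the scatter)), so all six pairs among the four compounds now lie within it, and nitrile, methyl, chloro and methoxy on the phenyl ring do not separate these compounds. Within the data shown here, compound 3 and compound 4 form the one pair here in which the phenyl ring stays and only its substituent is exchanged, methoxy in place of chloro on an aromatic carbon, and that exchange also stays within the scatter (a 1.2-fold higher number from compound 3 to compound 4 (0.07 log units; within the scatter)). No data at hand speak to the reason for these numbers.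

Open, from the compounds shown here alone, is whether a phenyl ring carrying an amine or a carboxylic acid would give a step beyond the scatter on this nitrogen. Equally open, going by these compounds, is whether a benzyl group or a longer alkyl chain in place of the phenyl ring would keep the number in the same range.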